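The source may hold more compounds than are shown below. What is called first, only, known or untested is meant among the compounds shown, and "the series" means these compounds.

Compound 1 `CCOC(=O)c1cnc2ccc(-c3ccccc3)cc2c1` gives > 7400 nM in a functional assay on RD cells (Homo sapiens) for inhibition, read by luminescence and ATP content, with a stated time of 72 h (on this read-out lower numbers stand for higher toxicity in this test and higher numbers for lower toxicity in this test), a value that is a limit of the assay and not a number.
Compound 2 `CC(C)(C)c1nc(-c2cnc3ccc(-c4ccc(N)cc4)cc3c2)no1` gives > 7400 nM in this assay, again a limit.
Compound 3 `Nc1ccc(-c2ccc3ncc(-c4noc(C(F)(F)F)n4)cc3c2)cn1` gives > 2500 nM in this assay, also a limit.

None of the three compounds has a measured number in this assay; every value is a limit. Compound 3 sits at the limit of > 2500 nM in this assay, at which 1 of the 3 values shown sits, whereas the other two compounds sit at the limit of > 7400 nM in this assay, at which 2 of the 3 values shown sit. Since all three are limits, nothing can be said about how compound 3 ranks against compound 1 or compound 2; the readings only show that none of them reached half-maximal toxicity within the tested range.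

The next compound, compound 4 `FC(F)(F)c1nc(-c2cnc3ccc(-c4ccc(Cl)cc4)cc3c2)no1`, has not yet been measured in this assay. It differs from compound 3 in one spot: 4-chlorophenyl in place of 6-aminopyridin-3-yl on an aromatic carbon. For the measured compounds named here, no pair of measured compounds shares a single change of this kind, so there is no measured step to lean on. Given that all three measured values are limits, with two sitting at the limit of > 7400 nM in this assay, at which 2 of the 3 values shown sit, the expectation is that compound 4 will likewise show no toxicity within the tested range, and the step that the limit leaves unreadable from compound 3 to compound 4 is estimated as no change beyond the scatter. Compound 4 is expected to give about 7400 nM in this assay, in a range from 2500 nM to 30000 nM, most probably reported only as a limit.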

Compound 4, half-maximal cytotoxic concentration: > 200000 nM
Compound 4 ended at the assay's limit (the forecaster's own chance of this, stated with the estimate: 80%); middle value at least 27-fold (1.43 log units) away from the limit.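

The change from compound 3 to compound 4 cannot be read as a step: both values in this assay are limits of the assay and not numbers. The compounds shown leave open the concentration at which any of them reaches half-maximal toxicity, and whether 4-chlorophenyl in place of 6-aminopyridin-3-yl alters toxicity at all.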